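A few compounds are considered here, and "the series" means these few. Any claim that something is new, unique, unknown or untested is made for them only; others in the source may bear on it.

Compound 1, `NC(=O)c1nn(-c2ccc3onc(N)c3c2)c2c(F)c(-c3ccc(N4CCCCC4=O)cc3F)ccc12`, in an assay on isolated protein for inhibition of Trypsin (Homo sapiens) (on this read-out higher numbers stand for weaker inhibition and lower numbers for stronger inhibition), gives > 10000 nM, which is a limit of the assay.
Compound 2, `CN(C)Cc1nccn1-c1ccc(-c2ccc3c(C(N)=O)nn(-c4ccc5onc(N)c5c4)c3c2F)c(F)c1`, in this assay gives > 10000 nM, also a limit.
Compound 3, `CN(C)Cc1ccncc1-c1ccc(-c2ccc3c(C(N)=O)nn(-c4ccc5onc(N)c5c4)c3c2F)c(F)c1`, in this assay gives > 10000 nM, again a limit.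

Compound 3 therefore stands at the edge of what this assay can read: the assay reported no number for it, only that its inhibition constant lies beyond its range. The same holds for the other two compounds, since (the limit of > 10000 nM in this assay, at which 3 of the 3 values shown sit).

Compound 4 is `CN(C)Cc1cnccc1-c1ccc(-c2ccc3c(C(N)=O)nn(-c4ccc5onc(N)c5c4)c3c2F)c(F)c1`. It shares the whole core with compound 3 and differs in one place: 3-((dimethylamino)methyl)pyridin-4-yl in place of 4-((dimethylamino)methyl)pyridin-3-yl on an aromatic carbon. The change swaps a group for another built from the same atoms, joined differently.

Within the data shown here, two measured steps bear on this position. The step that the two limits leave unreadable from compound 1 to compound 3 and the step that the two limits leave unreadable from compound 2 to compound 3 both connect compounds whose values are limits, so neither gives a readable size. Three quite different groups at this position leave the inhibition constant beyond the assay range, and nothing points to compound 4 behaving otherwise.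

Compound 4 is expected to give about 20000 nM in this assay, within 10000 nM to 100000 nM, most likely again reported only as a limit. The expected step that the limit leaves unreadable from compound 3 to compound 4 is thus estimated as none beyond the scatter.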

Compound 4, inhibition constant: > 10000 nM
Compound 4 ended at the assay's limit; the forecaster's own chance of this, stated with the estimate: 90%; the middle value does not contradict the limit.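

No step can be read between compound 4 and compound 1, compound 2 or compound 3, as each value is only a limit in this assay: the limit of > 10000 nM in this assay, at which 4 of the 4 values shown sit.

The compounds shown leave open how weakly each one actually inhibits the enzyme, and whether the groups exchanged among them differ in effect at all.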